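A few compounds are considered here, and "the series" means these few. Any claim that something is new, unique, unknown or untested is made for them only; others in the source may bear on it.

Working notes on the series. In a functional assay on H184B5F5/M10 cells (Homo sapiens) for antiproliferative activity, read by XTT assay, with a stated time of 72 h (on this read-out higher numbers stand for weaker inhibition and lower numbers for stronger inhibition), compound 2 `COc1ccc(-c2cc3ccccc3nc2/C=C/C(=O)c2ccc(OC)c(OC)c2)cc1` gives 7240 nM, the higher of the two numbers here; compound 1 `COc1ccc(-c2cc3ccccc3nc2/C=C/C(=O)c2ccc(O)cc2)cc1` gives 5690 nM, and the step of a 1.3-fold higher number from compound 1 to compound 2 (0.10 log units; within the scatter) stays within the scatter. Compound 3 `COc1ccc(-c2cc3ccccc3nc2/C=C/C(=O)c2ccc[nH]2)cc1` returns only a limit of this assay, > 10000 nM. Compound 4 `COc1ccc(-c2cc3ccccc3nc2/C=C/C(=O)c2c[nH]c3ccccc23)cc1` differs from compound 2 by 1H-indol-3-yl in place of 3,4-dimethoxyphenyl on a carbonyl carbon. Within the data shown here, two measured steps bear on this change: an at least 1.7-fold higher number from compound 1 to compound 3 (0.24 log units; that floor lies within the scatter) and an at least 1.3-fold higher number from compound 2 to compound 3 (0.14 log units; that floor lies within the scatter), both ending at the limit noted in the limit of > 10000 nM in this assay, at which 1 of the 3 values shown sits, so their true size stays open. For compound 4 a step upward in this assay or none beyond the scatter is expected, a 1.2-fold higher number from compound 2 to compound 4 (0.09 log units; within the scatter). Compound 4 is therefore estimated at 9000 nM, in the range 4000 nM to 20000 nM, with a real chance that only a limit is returned.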

Compound 4, half-maximal inhibitory concentration: > 10000 nM
Compound 4: no number, only a limit; the forecaster's own chance of this, stated with the estimate: 40%; at least 1.1-fold (0.04 log units) between middle value and limit.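

In this assay compound 4 gives only a limit, not a number, so both 1H-pyrrol-2-yl in compound 3 and the larger 1H-indol-3-yl on the carbonyl carbon end there: the limit of > 10000 nM in this assay, at which 2 of the 4 values shown sit. The readable steps are an at least 1.3-fold higher number from compound 2 to compound 4 (0.14 log units; that floor lies within the scatter) and an at least 1.7-fold higher number from compound 1 to compound 4 (0.24 log units; that floor lies within the scatter), so no loss against either phenyl compound is established. The step between the two limits cannot be read.

As far as these compounds go, how far compound 3 and compound 4 lie past the limit stays open. Also open, from the compounds shown here alone, is whether a dimethylamino group or a carboxylic acid on the phenyl ring would move the number beyond the scatter.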